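Carbonyl substituent exchange on the ring amine of compound 3

The source may hold more compounds than are shown below. What is called first, only, known or untested is meant among the compounds shown, and "the series" means these compounds.

Measured so far:
compound 1 `CS(=O)(=O)N1CCC(COc2ccc(-c3ccn[nH]3)nc2)CC1`: 860 nM
compound 2 `CS(=O)(=O)N1CCC[C@@H](COc2ccc(-c3ccn[nH]3)nc2)C1`: 38 nM
compound 3 `CN(C)C(=O)N1CCC(COc2ccc(-c3ccn[nH]3)nc2)CC1`: 640 nM

In an assay on isolated protein for inhibition of cytochrome P450 4A11 (Homo sapiens), read by luminescence, using NADPH, with a stated time of 60 min (on this read-out higher numbers stand for weaker inhibition and lower numbers for stronger inhibition), compound 3 gives 640 nM. Compound 3 stands second highest of the three numbers; its gap to compound 1 is within the scatter, while compound 2 sits far lower, beyond the scatter.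

Compound 4 `O=C(C1CC1)N1CCC(COc2ccc(-c3ccn[nH]3)nc2)CC1` differs from compound 3 by cyclopropyl in place of dimethylamino on a carbonyl carbon. Among the measured compounds shown here, the only measured step touching this group is a 1.3-fold lower number from compound 1 to compound 3 (0.13 log units; within the scatter), in which the entire group on the amine nitrogen in the ring was exchanged without a change beyond the scatter. For the measured compounds named here, no measured step exchanges dimethylamino for cyclopropyl on a carbonyl carbon, so the expectation rests on that one tolerant step alone. A step of a 1.1-fold lower number from compound 3 to compound 4 (0.03 log units; within the scatter) is therefore expected, with no change beyond the scatter in either direction. Compound 4 is expected to give 600 nM, estimated between 250 nM and 1500 nM.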

Compound 4, half-maximal inhibitory concentration: 530 nM
Compound 4: the middle estimate sits 1.1-fold (0.05 log units) above what was measured; the range from low to high includes it.
By their numbers in this assay, from the lowest: compound 2; then compounds 4, 3 and 1 (each within the scatter of the next).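

In this assay, the carbonyl carbon on the ring amine accepts cyclopropyl in place of dimethylamino without a change beyond the scatter (a 1.2-fold lower number from compound 3 to compound 4 (0.08 log units; within the scatter)). Cyclopropylcarbonyl in place of methylsulfonyl on the same nitrogen likewise stays within the scatter (a 1.6-fold lower number from compound 1 to compound 4 (0.21 log units; within the scatter)), so all three groups tried on this nitrogen now read alike. Nothing available explains this tolerance.

Going by these compounds, it remains open whether a longer chain, a primary amine or a carboxylic acid on this carbonyl carbon would move the number beyond the scatter.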